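The source may report more compounds than this note shows. Statements on the series, on what has been measured and on what is new or still open speak of the compounds shown alone.

In a functional assay on COLO 205 cells (Homo sapiens) for inhibition, read by sulforhodamine B assay (on this read-out higher numbers stand for weaker inhibition of growth and lower numbers for stronger inhibition of growth), compound 1 `COc1ccc(-c2ccc(-c3ccc(-c4nc5ccccc5[nH]4)cc3)cc2)cc1` gives 45200 nM and compound 2 `Oc1cccc2[nH]c(-c3ccc(-c4ccc(-c5ccc(F)cc5)cc4)cc3)nc12` gives 1220 nM. Compound 3 `Oc1ccc(-c2ccc(-c3ccc(-c4nc5c(O)cccc5[nH]4)cc3)cc2)cc1` gives 2600 nM, the second highest of the three numbers. Compound 4 `COc1ccc(-c2ccc(-c3ccc(-c4nc5c(O)cccc5[nH]4)cc3)cc2)cc1` differs from compound 3 by methyl in place of hydrogen on an oxygen on an aromatic ring, so 4-hydroxyphenyl becomes 4-methoxyphenyl. Among the measured compounds shown here, only one measured step changes that same hydroxy: a 2.1-fold higher number from compound 2 to compound 3 (0.33 log units; beyond the scatter), a modest step with hydroxy in place of fluoro on an aromatic carbon. For the measured compounds named here, no measured step adds the methyl itself, so in this assay no change beyond the scatter is expected. The estimated step is a 1.2-fold higher number from compound 3 to compound 4 (0.06 log units; within the scatter) as a weak lean only. Compound 4 is expected at 3000 nM with an estimated range from 1000 nM to 9000 nM overall.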

Compound 4, concentration for 50% growth inhibition: 1630 nM
The estimate for compound 4 lay 1.8-fold (0.26 log units) above the measured number, and the stated range covers the measured number.
By their numbers in this assay, from the lowest: compounds 2, 4 and 3 (each within the scatter of the next, the first and the last beyond it); then compound 1.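

In this assay the change from 4-hydroxyphenyl to 4-methoxyphenyl stays within the scatter (a 1.6-fold lower number from compound 3 to compound 4 (0.20 log units; within the scatter)), and methoxy in place of fluoro at that end does too (a 1.3-fold higher number from compound 2 to compound 4 (0.13 log units; within the scatter)), so this position accepts all three groups without a clear difference between the methoxy compound and either of the others. The large step lies elsewhere, with a hydroxy added to the core (a 28-fold lower number from compound 1 to compound 4 (1.44 log units; beyond the scatter)). Nothing available explains these steps. As far as these compounds go, whether a longer chain on that oxygen, or an amine at that position, would also stay within the scatter remains open.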